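Pyridin-4-yl in place of 3,4-dimethoxyphenyl

The source may hold more compounds than are shown below. What is called first, only, known or untested is meant among the compounds shown, and "the series" means these compounds.

In a functional assay on A549 cells (Homo sapiens) for inhibition, read by MTT assay, with a stated time of 72 h (a higher number here means a weaker inhibitor, a lower number a stronger inhibitor), compound 3 `COc1ccc(-c2cc(C(=O)N3CCC4(CC3)CC(=O)c3nn(C(C)(C)C)cc3O4)c3ccccc3n2)cc1OC` gives 2030 nM, within the scatter of compound 2 `CC(C)(C)n1cc2c(n1)C(=O)CC1(CCN(C(=O)c3cc(-c4ccc(Cl)cc4)nc4ccccc34)CC1)O2` at 2330 nM. Compound 1 `Cc1ccc(-c2cc(C(=O)N3CCC4(CC3)CC(=O)c3nn(C(C)(C)C)cc3O4)c3ccccc3n2)cc1` gives 5300 nM. Compound 4 `CC(C)(C)n1cc2c(n1)C(=O)CC1(CCN(C(=O)c3cc(-c4ccncc4)nc4ccccc34)CC1)O2` carries pyridin-4-yl in place of 3,4-dimethoxyphenyl on an aromatic carbon. Three measured steps alter the group at this place: a 2.3-fold lower number from compound 1 to compound 2 (0.36 log units; beyond the scatter) and a 2.6-fold lower number from compound 1 to compound 3 (0.42 log units; beyond the scatter) are modest, while a 1.1-fold lower number from compound 2 to compound 3 (0.06 log units; within the scatter) stays within the scatter. Among the measured compounds shown here, no measured compound has a hetero atom in this ring, so direction is poorly supported. A small upward shift in this assay is expected, probably not beyond the scatter. The estimated step is a 1.7-fold higher number from compound 3 to compound 4 (0.24 log units; within the scatter). For compound 4 the estimated value is 3500 nM, with an expected range of 1500 nM to 8500 nM.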

Compound 4, half-maximal inhibitory concentration: 550 nM
Estimate against measurement, compound 4: 6.4-fold (0.80 log units) above, outside the stated range (below it).
By their numbers in this assay, from the lowest: compound 4; then compounds 3 and 2 (each within the scatter of the next); then compound 1.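

In this assay, among the compounds shown here, pyridin-4-yl is the first group at this place, on the carbon next to the ring nitrogen, to stand clearly apart from all the others: a 3.7-fold lower number from compound 3 to compound 4 (0.57 log units; beyond the scatter) and a 4.2-fold lower number from compound 2 to compound 4 (0.63 log units; beyond the scatter) and a 9.6-fold lower number from compound 1 to compound 4 (0.98 log units; beyond the scatter) all point the same way. The carbon-only aromatic rings gave smaller steps among themselves, so a ring with a hetero atom is accepted here and gives the lowest number of the four. Nothing measured explains this shift.

Going by these compounds, whether pyridin-3-yl or pyridin-2-yl would match pyridin-4-yl remains open. So does the outcome with a pyrimidine ring or an aminophenyl group at this place.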